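Step from compound 3 to compound 4

The source may report more compounds than this note shows. Statements on the series, on what has been measured and on what is new or still open speak of the compounds shown alone.

Measured in a functional assay on K562 cells (Homo sapiens) for antiproliferative activity, read by MTT assay, with a stated time of 72 h; on this read-out higher numbers stand for weaker inhibition and lower numbers for stronger inhibition:
compound 1 `COc1ccccc1-c1c(C(=O)c2cc(OC)c(OC)c(OC)c2)sc2ccccc12` gives 3400 nM
compound 2 `COc1ccc(-c2c(C(=O)c3cc(OC)c(OC)c(OC)c3)sc3ccccc23)c(OC)c1` gives 4100 nM
compound 3 `COc1ccc(-c2c(C(=O)c3cc(OC)c(OC)c(OC)c3)sc3ccccc23)cc1C` gives > 10000 nM

For compound 3 the value > 10000 nM is a limit and not a number. Among the measured compounds shown here, it stands at the limit of > 10000 nM in this assay, at which 1 of the 3 values shown sits, and is the only such value of the three.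

Next is compound 4 `CCOc1ccc(Nc2c(C(=O)c3cc(OC)c(OC)c(OC)c3)sc3ccccc23)cc1`, with the change (4-ethoxyphenyl)amino in place of 4-methoxy-3-methylphenyl on an aromatic carbon.

For the measured compounds named here, three measured steps concern this same carbon: a 1.2-fold higher number from compound 1 to compound 2 (0.08 log units; within the scatter), an at least 2.9-fold higher number from compound 1 to compound 3 (0.46 log units; beyond the scatter) and an at least 2.4-fold higher number from compound 2 to compound 3 (0.38 log units; beyond the scatter). None of them brings in an amino group, so they bear on the change only indirectly. With compound 1 at 3400 nM as the nearest measured number, a modest move to a lower number in this assay is expected. It remains quite possible that compound 4 also ends at a limit of the assay.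

The expected step is an at least 2.0-fold lower number from compound 3 to compound 4 (0.30 log units; that floor lies within the scatter). For compound 4 the estimated value is 5000 nM, with an expected range of 1500 nM to 10000 nM.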

Compound 4, half-maximal inhibitory concentration: 200 nM
For compound 4 the middle estimate is 25-fold (1.40 log units) above the measured one; measured number below the stated range.
By their numbers in this assay, from the lowest: compound 4; then compounds 1 and 2 (each within the scatter of the next). At a limit, above all of these: compound 3.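

In this assay, among the compounds shown here, (4-ethoxyphenyl)amino on this aromatic carbon gives a 17-fold lower number from compound 1 to compound 4 (1.23 log units; beyond the scatter) and a 21-fold lower number from compound 2 to compound 4 (1.31 log units; beyond the scatter), both large, so this position tolerates more than the directly attached substituted phenyl groups of the earlier compounds suggested. The comparison with the third phenyl compound gives an at least 50-fold lower number from compound 3 to compound 4 (1.69 log units; beyond the scatter), so the same change is also large from that side. Compound 3 is held at a limit and not a number: the limit of > 10000 nM in this assay, at which 1 of the 4 values shown sits.

The change brings in the amino link and swaps the ring substituent for ethoxy in one step, so the compounds shown do not separate the two contributions. A (4-methoxyphenyl)amino group, or a methylated amine at the same carbon with the 4-ethoxyphenyl ring kept, would bear directly on that question.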